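Swapping the Aryl Ether for a Methyl Group

The compounds below may be only part of what the source reports. "The series", "measured", "known", "first", "only" and "open" are said of these compounds alone.

Measured so far:
Compound 1, `CN(C)C(=O)c1cccnc1NCCCN1CCN(c2ccccc2OC(F)(F)F)CC1`: 3.16 nM
Compound 2, `CN(C)C(=O)c1cccnc1NCCCN1CCN(c2ccccc2OCC(F)(F)F)CC1`: 0.1 nM

Both were tested in a functional assay for antagonist activity at Alpha-1A adrenergic receptor (Oryctolagus cuniculus); a higher number here means weaker binding, a lower number tighter binding. Among the compounds with values here, compound 2 stands at the lowest of the two numbers, with compound 1 the nearest at a higher value; the one measured step, a 32-fold lower number from compound 1 to compound 2 (1.50 log units; beyond the scatter), is large and points toward tighter binding when the group on the oxygen grows. Compound 3, `Cc1ccccc1N1CCN(CCCNc2ncccc2C(=O)N(C)C)CC1`, differs from compound 2 in one place: methyl in place of 2,2,2-trifluoroethoxy on an aromatic carbon. Within the data shown here, no measured step covers this kind of change, since the only step alters what hangs on the oxygen rather than removing the oxygen itself. Losing a group that helped so much suggests a move back toward weaker binding, so the expected step is a 30-fold higher number from compound 2 to compound 3 (1.48 log units; beyond the scatter), with wide uncertainty. Compound 3 is therefore estimated at 3 nM in this assay, likely between 0.4 nM and 30 nM.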

Compound 3, dissociation constant: 2 nM
The estimate for compound 3 lay 1.5-fold (0.18 log units) above the measured number; measured number inside the range.
By their numbers in this assay, from the lowest: compound 2; then compounds 3 and 1 (each within the scatter of the next).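

In this assay replacing 2,2,2-trifluoroethoxy, with its six heavy atoms, by methyl, with one, on this aromatic carbon gives a 20-fold higher number from compound 2 to compound 3 (1.30 log units; beyond the scatter) and so gives up the low number that set compound 2 apart. Replacing trifluoromethoxy by methyl gives a 1.6-fold lower number from compound 1 to compound 3 (0.20 log units; within the scatter) and this step lies within the scatter, so a group without oxygen serves as well here as trifluoromethoxy, and among these three groups only 2,2,2-trifluoroethoxy stands out. No measurement at hand explains why this group differs from the other two.

On these data alone, whether a methoxy or an ethoxy group, which carry no fluorine, would match 2,2,2-trifluoroethoxy stays open. So does whether a longer chain on the oxygen, such as propoxy, would give a lower number still in this assay.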